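The source may report more compounds than this note shows. Statements on the series, on what has been measured and on what is new or still open speak of the compounds shown alone.

Of the compounds shown here, two built on the same core have been measured. Compound 1 `COc1ccc(C(=O)c2cc(OC)c(OC)c(OC)c2)cc1NC(=O)/C=C/c1ccc(C(F)(F)F)cc1` gives 800 nM in a functional assay on ME-180 cells (Homo sapiens) for cytotoxicity, read by MTT assay, with a stated time of 72 h; on this read-out higher numbers stand for weaker inhibition and lower numbers for stronger inhibition. Compound 2 `COc1ccc(C(=O)c2cc(OC)c(OC)c(OC)c2)cc1NC(=O)/C=C/c1ccc(N)cc1` gives 16000 nM in this assay, the higher of the two numbers. Compound 3 `COc1ccc(C(=O)c2cc(OC)c(OC)c(OC)c2)cc1NC(=O)/C=C/c1ccc([N+](=O)[O-])cc1` differs from compound 2 by nitro in place of amino on an aromatic carbon. Within the data shown here, the only measured step that bears on this change is a 20-fold higher number from compound 1 to compound 2 (1.30 log units; beyond the scatter), where the amino entered; removing the amino again might move the number back toward compound 1, but no step tests nitro itself. Compound 3 is therefore expected to give 2500 nM, within 600 nM to 10000 nM. The expected step is a 6.4-fold lower number from compound 2 to compound 3 (0.81 log units; beyond the scatter).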

Compound 3, half-maximal inhibitory concentration: 9300 nM
Estimate against measurement, compound 3: 3.7-fold (0.57 log units) below; low and high end bracket the measured number.
By their numbers in this assay, from the lowest: compound 1; then compounds 3 and 2 (each within the scatter of the next).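

In this assay, replacing amino with nitro on the aromatic carbon gives a 1.7-fold lower number from compound 2 to compound 3 (0.24 log units; within the scatter), so this assay does not separate these two groups at this position. Replacing trifluoromethyl with nitro gives a 12-fold higher number from compound 1 to compound 3 (1.07 log units; beyond the scatter), which shows that the earlier gap between trifluoromethyl and amino was not specific to amino. Among these three compounds, only compound 1, with trifluoromethyl, stands apart.

As far as these compounds go, a nitrile or a chlorine atom at this position could fall with trifluoromethyl or with amino and nitro, which remains open. Nothing available here explains why trifluoromethyl stands apart.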